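A Chloro Added to a Weak Growth Inhibitor

This account rests on a few compounds, and the source may have more. Where it says the series, first, only, none or still open, it means among the compounds named here.

Measured so far in a functional assay on NCI/ADR-RES cells (Homo sapiens) for inhibition; on this read-out lower numbers stand for stronger inhibition of growth and higher numbers for weaker inhibition of growth:
- Compound 1 `O=S(=O)(/C=C/c1ccc(Cl)cc1)Cc1ccc(Nc2ncnc3ccccc23)cc1`: > 100000 nM (a limit, not a number)
- Compound 2 `O=S(=O)(/C=C/c1ccc(F)cc1Cl)Cc1ccc(Nc2ncnc3ccccc23)cc1`: 66000 nM

Within the data shown here, compound 2 gives 66000 nM, the only true number so far. Among the measured compounds shown here, its one neighbour offers no exact comparison, since the top of the scale is set by the limit of > 100000 nM in this assay, at which 1 of the 2 values shown sits.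

The next molecule is compound 3 `O=S(=O)(/C=C/c1ccc(F)cc1Cl)Cc1ccc(Nc2ncnc3cc(Cl)ccc23)cc1`. The change from compound 2 is chloro in place of hydrogen on an aromatic carbon of the shared core.

For the measured compounds named here, only one measured step exists, an at least 1.5-fold lower number from compound 1 to compound 2 (0.18 log units; that floor lies within the scatter). That step lies in a different part of the molecule and does not go beyond the scatter, so it gives no direct guide to this change. Going by the values given here, no measured pair shows what chloro does at this place on the core. No step beyond the scatter is therefore expected in this assay, and no direction can be favoured with confidence.

The expected step is a 1.3-fold lower number from compound 2 to compound 3 (0.12 log units; within the scatter).

For compound 3 the estimated value is 50000 nM, with an expected range from 15000 nM to 100000 nM.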

Compound 3, concentration for 50% growth inhibition: > 100000 nM
Compound 3 was reported as a limit; the forecaster's own chance of this, stated with the estimate: 25%; middle value at least 2.0-fold (0.30 log units) from the limit.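

In this assay, compound 3 gives > 100000 nM, which is a limit and not a number. Going by these compounds, the step is an at least 1.5-fold higher number from compound 2 to compound 3 (0.18 log units; that floor lies within the scatter), so chloro in place of hydrogen at this place on the shared core brings no sign of stronger inhibition of growth, while the true size of the step stays unknown. This is the first measured change on the core rather than on the 2-chloro-4-fluorophenyl end of the molecule, and it puts a second compound at the top of the scale: the limit of > 100000 nM in this assay, at which 2 of the 3 values shown sit.

On these data alone, it remains open whether a different group at this same place, such as an amine or a carboxylic acid, would bring the number clearly down from that limit, and whether chloro on another carbon of the core would behave as it does here. With only one true number among the compounds shown, the data cannot yet say whether any change to the core strengthens or weakens inhibition of growth.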